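From compound 1 to compound 3: dropping the ethoxy

A few compounds are considered here, and "the series" means these few. Any claim that something is new, unique, unknown or untested is made for them only; others in the source may bear on it.

Compound 1 `CCOC1c2cc(OCc3cc(C)cc(C)c3)c(OCc3cc(C)cc(C)c3)cc2CCN1C(=O)OC(C)(C)C`: > 20000 nM (a limit)
Compound 2 `CCC[C@@H]1C[C@H](O)C/C=C(/CC)[C@H]2c3cc(OCc4ccccc4)c(OCc4ccccc4)cc3CCN12`: > 20000 nM (a limit)

Both results come from a functional assay on DU-145 cells (Homo sapiens) for inhibition, read by MTT assay, with a stated time of 24 h; on this read-out lower numbers stand for stronger inhibition and higher numbers for weaker inhibition. Compound 1 stands at a limit of the assay and not at a number: > 20000 nM. Compound 2 also gives only a limit, > 20000 nM. The whole picture so far is the limit of > 20000 nM in this assay, at which 2 of the 2 values shown sit. For the measured compounds named here, no measured step connects the two compounds, so the data offer no direct guide to how a single structural change moves the result.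

Compound 3 `Cc1cc(C)cc(COc2cc3c(cc2OCc2cc(C)cc(C)c2)CN(C(=O)OC(C)(C)C)CC3)c1` keeps the core of compound 1 and differs in one place: hydrogen in place of ethoxy on a saturated ring carbon. In plain words, hydrogen takes the place of ethoxy on a saturated ring carbon, next to the ring nitrogen, and the tert-butoxycarbonyl group stays.

With compound 1 at the limit of > 20000 nM as the only anchor, no step beyond the scatter is expected in this assay, and another limit is the likeliest outcome. The expected step is a number no higher from compound 1 to compound 3 (the limit leaves the size open). The estimated value for compound 3 is 20000 nM, with an expected range from 7000 nM to 40000 nM.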

Compound 3, half-maximal inhibitory concentration: > 20000 nM
Compound 3: no number, only a limit; the forecaster's own chance of this, stated with the estimate: 70%; the middle value lies on the limit itself.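

In this assay compound 3 gives only a limit, > 20000 nM. For the compounds shown here, compound 1 also stands at a limit, so no step from compound 1 to compound 3 can be read. The compounds shown leave open how far each lies beyond that limit and what change would give a real number, since all that can be seen is this: the limit of > 20000 nM in this assay, at which 3 of the 3 values shown sit.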